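Hydrogen in place of cyano: compound 1 to compound 3

A few compounds are considered here, and "the series" means these few. Any claim that something is new, unique, unknown or untested is made for them only; others in the source may bear on it.

Measured in a toxicity assay on Vero cells (Chlorocebus sabaeus) for inhibition; a lower number here means that less compound is needed, a higher number that more compound is needed for the effect:
- compound 1 `COc1cccc(NC(=O)c2nnn(Cc3ccc(C#N)cc3)c2N)c1`: > 50100 nM (a limit)
- compound 2 `COc1cccc(NC(=O)c2nnn(C(C)c3ccc(C(C)(C)C)cc3)c2N)c1`: 39800 nM

Compound 1 shows the reading > 50100 nM, which is a limit and not a number. For the measured compounds named here, compound 2 gives 39800 nM, the only numeric reading so far. Compound 3 `COc1cccc(NC(=O)c2nnn(Cc3ccccc3)c2N)c1` carries hydrogen in place of cyano on an aromatic carbon, para to a large group (hydrogen in place of cyano on an aromatic carbon). Going by the values given here, no measured pair isolates this change, so a number no higher from compound 1 to compound 3 (the limit leaves the size open) is expected to show no change beyond the scatter in this assay. For compound 3 the estimated value is 50000 nM, with an expected range from 25000 nM to 100000 nM.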

Compound 3, half-maximal effective concentration: > 50100 nM
Compound 3: no number, only a limit; the forecaster's own chance of this, stated with the estimate: 75%; at least 1.0-fold (0.00 log units) between middle value and limit.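

Compound 1 and compound 3 both read as limits, so no step can be read between them: the limit of > 50100 nM in this assay, at which 2 of the 3 values shown sit. The compounds shown leave open whether the change from 4-cyanophenyl to phenyl shifts the reading at all.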